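The compounds below may be only part of what the source reports. "The series", "measured", "known", "first", "only" and "open" are said of these compounds alone.

Compound 1 `COc1ccccc1-c1cccc(S(=O)(=O)N2CCC(N3CCC(C)CC3)CC2)c1` gives 0.25 h in an ADME assay on S9 fraction from liver (Mus musculus, strain ICR/CD-1) for metabolic stability, read by LC-MS, using NADPH, with a stated time of 5 min, tested at 2 uM; a higher number here means that the compound lasts longer, a lower number that the compound disappears faster.
Compound 2 `CC1CCN(C2CCN(S(=O)(=O)c3ccc(Br)cc3OC(F)(F)F)CC2)CC1` gives 0.0833 h in this assay.
Compound 3 `Cc1nc(Cl)sc1S(=O)(=O)N1CCC(N2CCC(C)CC2)CC1` gives 0.167 h in this assay.

All three compounds share a core built from two linked saturated rings joined through a sulfonyl group to an aromatic ring, and all disappear quickly in this assay. Compound 1 holds the highest of the three numbers. Compound 3 sits close to it, a difference that lies within the usual scatter of this measurement, so no order between the two can be claimed. Compound 2 lies further away, a gap beyond the scatter.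

Compound 4 `Cc1ccc(-c2cccc(S(=O)(=O)N3CCC(N4CCC(C)CC4)CC3)c2)cc1` has not been measured. It differs from compound 1 in one place: 4-methylphenyl in place of 2-methoxyphenyl on an aromatic carbon. Among the measured compounds shown here, no pair of measured compounds shows this particular change, so there is no step from which to read off its effect. The step from compound 1 to compound 4 is expected to be small, a 1.3-fold lower number from compound 1 to compound 4 (0.10 log units; within the scatter), most likely within the scatter and with no clear direction. Compound 4 is therefore estimated at 0.2 h, with a range from 0.08 h to 0.5 h.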

Compound 4, half-life: 1.92 h
The estimate for compound 4 lay 9.6-fold (0.98 log units) below the measured number, and the stated range ends below it.
By their numbers in this assay, from the lowest: compounds 2, 3 and 1 (each within the scatter of the next, the first and the last beyond it); then compound 4.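

Swapping the aromatic group on this carbon changes the result in this assay far more than the earlier compounds could suggest, with a 7.7-fold higher number from compound 1 to compound 4 (0.89 log units; beyond the scatter), a step beyond the scatter. Among the compounds shown here, it is the first comparison here between two compounds that differ in one place, and it shows that the half-life responds strongly to a change at this position, even though the two groups are nearly the same size by heavy-atom count. No available evidence accounts for this gain.

The compounds shown leave open whether the gain follows the loss of the methoxy group, the arrival of the methyl group or the place each holds on the phenyl ring, which 4-methoxyphenyl and 2-methylphenyl could separate. Also open, from the compounds shown here alone, is how an unsubstituted phenyl, or a phenyl carrying an amine, would behave at this carbon in this assay.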